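This account rests on a few compounds, and the source may have more. Where it says the series, first, only, none or still open, it means among the compounds named here.

In a physicochemical assay for solubility, read by turbidimetry, in phosphate buffer, with a stated time of 24 h, at pH 7.4 (on this read-out lower numbers stand for lower solubility and higher numbers for higher solubility), compound 1 `CCNC(=O)Nc1nc2cc(-c3cnc(N4CCC(C)(C(=O)O)CC4)nc3)cc(-c3ccccn3)c2s1` gives > 800 ug/mL, which is a limit of the assay and not a number. Compound 2 `CCNC(=O)Nc1nc2cc(-c3cnc(N4CCC(C(=O)O)(S(C)(=O)=O)CC4)nc3)cc(-c3ccccn3)c2s1`, with methylsulfonyl in place of methyl on a saturated ring carbon, gives > 800 ug/mL, which is also a limit. For the measured compounds named here, the only measured change is therefore a step that the two limits leave unreadable from compound 1 to compound 2, so it offers no size to carry forward. Compound 3 `CCNC(=O)Nc1nc2cc(-c3cnc(N4CCC(C)(C(=O)O)C4)nc3)cc(-c3ccccn3)c2s1` has a different change, with 3-carboxy-3-methylpyrrolidin-1-yl in place of 4-carboxy-4-methylpiperidin-1-yl on an aromatic carbon. The evidence available is the limit of > 800 ug/mL in this assay, at which 2 of the 2 values shown sit, so compound 3 is expected to land near that limit too, with no step beyond the scatter and no clear direction. The expected change is a number no higher from compound 1 to compound 3 (the limit leaves the size open). For compound 3, the estimated solubility is 800 ug/mL, with an expected range from 400 ug/mL to 1600 ug/mL.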

Compound 3, solubility: > 800 ug/mL
Compound 3 gave a limit, no number; the forecaster's own chance of this, stated with the estimate: 75%; the middle value sits exactly at the limit.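

Compound 1 and compound 3 each give only a limit of the assay in this assay, so no step can be read between them. The true solubility of each compound, and any difference between them, stays open: the limit of > 800 ug/mL in this assay, at which 3 of the 3 values shown sit.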